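The compounds below may be only part of what the source reports. "The series", "measured", "known", "first", "only" and "open" are said of these compounds alone.

Measured so far: compound 1 `COc1cccc(C(=O)CC2C(C#N)=C(N)Oc3ccc(Br)cc32)c1`, compound 2 `COc1cc(Br)cc2c1OC(N)=C(C#N)C2CC(=O)c1ccc(C)cc1`, compound 3 `N#CC1=C(N)Oc2ccc(Br)cc2C1CC(=O)c1ccc(Br)cc1`.

In a functional assay on MCF7 cells (Homo sapiens) for antiproliferative activity, read by sulforhodamine B assay, with a stated time of 72 h, tested at 30 uM (on this read-out higher numbers stand for a weaker effect at the one concentration tested and lower numbers for a stronger effect), compound 1 gives 34.4%, compound 2 gives 52.8% and compound 3 gives 34.2%. Compound 3 thus has the lowest number of the three, though compound 1 sits within the scatter of it; only compound 2 stands apart with a clearly higher number.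

Compound 4 `Cc1ccc(C(=O)CC2C(C#N)=C(N)Oc3ccc(Br)cc32)cc1` differs from compound 3 by methyl in place of bromo on an aromatic carbon. Within the data shown here, the one measured step on this phenyl ring, a number 0.2 percentage points lower from compound 1 to compound 3 (within the scatter), was small. Compound 2 carries the same 4-methylphenyl but also a methoxy on the core, so it bears only loosely. The step of a number 9.8 percentage points higher from compound 3 to compound 4 (within the scatter) is expected to be modest; compound 4 is estimated at 44%, between 30% and 60%.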

Compound 4, a percentage reported as activity, at one concentration (the size of the read-out at that concentration, not a potency): 32.3%
Beside the measured number, compound 4's estimate is 11.7 percentage points above it; the measured number falls inside the stated range.
By their numbers in this assay, from the lowest: compounds 4, 3 and 1 (each within the scatter of the next); then compound 2.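

In this assay the 4-methylphenyl and 4-bromophenyl groups cannot be told apart, with a number 1.9 percentage points lower from compound 3 to compound 4 (within the scatter) after the swap, and 3-methoxyphenyl joins them with a number 2.1 percentage points lower from compound 1 to compound 4 (within the scatter) on the same carbonyl carbon. Among these compounds, with 4-methylphenyl held fixed, hydrogen in place of methoxy on the core gives a number 20.5 percentage points lower from compound 2 to compound 4 (beyond the scatter) and is the only one of these steps beyond the scatter. Nothing at hand explains these results.

From the compounds shown here alone, whether an amine or a carboxylic acid on this phenyl ring would shift the number remains open. So does whether the methoxy step on the core would repeat with 4-bromophenyl in place of 4-methylphenyl.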